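Swapping an Isobutyl for a Cyclohexyl on the Amine

The source may report more compounds than this note shows. Statements on the series, on what has been measured and on what is new or still open speak of the compounds shown alone.

Compound 1, `CC(C)CNC(=C\C(=O)/C=C/c1ccc(O)cc1)/C=C/c1ccc(O)cc1`, was tested in a functional assay on EA.hy 926 cells (Homo sapiens), read by fluorescence, tested at 1 uM (a lower number here means a weaker effect, a higher number a stronger effect of the compound at the concentration tested), where compound 1 gives 100%. Among the three measured compounds this is the second highest number. Compound 2, `COc1cc(/C=C/C(=O)/C=C(/C=C/c2ccc(OC(C)=O)c(OC)c2)NCC(C)C)ccc1OC(C)=O`, gives 104%, a value within the usual scatter of compound 1, so the two cannot be told apart. Compound 3, `CC(=O)Oc1ccc(/C=C/C(=O)/C=C(/C=C/c2ccc(OC(C)=O)cc2)NCC(C)C)cc1`, gives 60%, which lies beyond the scatter and lower than compound 1. Compound 4, `O=C(/C=C(/C=C/c1ccc(O)cc1)NC1CCCCC1)/C=C/c1ccc(O)cc1`, has not yet been measured. It differs from compound 1 in one place: cyclohexyl in place of isobutyl on an amine nitrogen. Going by the values given here, no pair of measured compounds shows what this change does. Compound 4 is expected to give about 95%, with a range from 70% to 115%. That estimate means a step of a number 5 percentage points lower from compound 1 to compound 4 (within the scatter), expected to stay within the scatter or fall only slightly.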

Compound 4, a percentage reported as activity, at one concentration (the size of the read-out at that concentration, not a potency): 129%
Estimate against measurement, compound 4: 34 percentage points below; measured number outside the range, above it.
By their numbers in this assay, from the lowest: compound 3; then compounds 1 and 2 (each within the scatter of the next); then compound 4.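

In this assay, the group on this amine nitrogen matters: cyclohexyl in place of isobutyl gives a number 29 percentage points higher from compound 1 to compound 4 (beyond the scatter). Going by these compounds alone, this is the first single change here whose effect can be read, and it shows that a six-membered carbon ring on this nitrogen keeps the activity and raises it. Nothing available accounts for the gain.

Still open, as far as these compounds go, is whether the ring itself or simply the larger number of carbons matters; a cyclopentyl ring or a straight hexyl chain on this nitrogen would help separate the two. From the compounds shown here alone, whether cyclohexyl brings a similar gain on the acetate-bearing compound 3 also remains open.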